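Bromo for Chloro on Two Different Cores

The source may hold more compounds than are shown below. What is called first, only, known or untested is meant among the compounds shown, and "the series" means these compounds.

Measured compounds:
compound 1 `COc1ccc2nc(C)cc(OCC(=O)Nc3ccc(Br)cc3)c2c1` — in an ADME assay on HepG2 cells (Homo sapiens) for cytotoxicity, read by trypan blue exclusion, with a stated time of 48 h, in the presence of a further agent that is not named here (on this read-out higher numbers stand for lower toxicity in this test and lower numbers for higher toxicity in this test), compound 1 gives > 125000 nM, a limit of the assay rather than a number.
compound 2 `COc1ccc2nc(C)cc(OCC(=O)Nc3ccc(Cl)cc3)c2c1` — compound 2 gives 89900 nM.
compound 3 `COc1ccccc1NC(=O)COc1cc(C)nc2ccc(Cl)cc12` — compound 3 gives 140000 nM.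

From compound 2 to compound 1 the change is bromo in place of chloro on an aromatic carbon. Going by the values given here, the step it made was an at least 1.3-fold higher number from compound 2 to compound 1 (0.14 log units; that floor lies within the scatter), and the limit of > 125000 nM in this assay, at which 1 of the 3 values shown sits, is the only evidence bearing on its size.

Compound 4 `COc1ccccc1NC(=O)COc1cc(C)nc2ccc(Br)cc12` is not yet measured. It differs from compound 3 by bromo in place of chloro on an aromatic carbon. This is the same kind of change as that from compound 2 to compound 1, but not the same: in compound 1 the ring is a six-membered aromatic ring of carbon only, para to a large group, whereas in compound 4 the ring is part of a fused or bridged system of two rings, meta to a fused ring and para to a fused ring. The difference between the two cores is not broken down here.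

Resting on the small step seen from compound 2 to compound 1 an at least 1.3-fold higher number from compound 2 to compound 1 (0.14 log units; that floor lies within the scatter), the step from compound 3 to compound 4 is expected to be a 1.2-fold higher number from compound 3 to compound 4 (0.08 log units; within the scatter). Compound 4 is therefore estimated at 170000 nM, expected to fall between 75000 nM and 380000 nM.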

Compound 4, half-maximal cytotoxic concentration: > 125000 nM
Compound 4 was reported as a limit (the forecaster's own chance of this, stated with the estimate: 35%); the middle value is on the limit's open side.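

Compound 4 gives a limit rather than a number, so no step from compound 3 to compound 4 can be read: the limit of > 125000 nM in this assay, at which 2 of the 4 values shown sit.

From the compounds shown here alone, how large a change bromo in place of chloro brings on either core remains open.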